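The source may report more compounds than this note shows. Statements on the series, on what has been measured and on what is new or still open speak of the compounds shown alone.

Compound 1 `O=C(OCCCc1ccccc1)c1cc(-n2cc(-c3cccc(O)c3)nn2)ccc1O` in a functional assay on CCRF-CEM cells (Homo sapiens) for inhibition, read by MTT assay, with a stated time of 2 days, tested at 10 uM (a lower number here means less inhibition, a higher number more inhibition at the concentration tested (going by the name of the read-out)), gives 9%. Compound 2 `COC(=O)c1cc(-n2cc(-c3cccc(O)c3)nn2)ccc1O` gives 5%, and compound 3 `O=C(O)c1cc(-n2cc(-c3cccc(O)c3)nn2)ccc1O` gives 3%. The steps of a number 4 percentage points lower from compound 1 to compound 2 (within the scatter), a number 6 percentage points lower from compound 1 to compound 3 (within the scatter) and a number 2 percentage points lower from compound 2 to compound 3 (within the scatter) all lie within the scatter, so on these numbers the three compounds cannot be told apart, and all show little inhibition. Each of those steps alters only the group on the oxygen next to the carbonyl. Compound 4 `COc1ccc(OC)c(-c2cn(-c3ccc(O)c(C(=O)OCCCc4ccccc4)c3)nn2)c1` differs from compound 1 elsewhere: 2,5-dimethoxyphenyl in place of 3-hydroxyphenyl on an aromatic carbon. Among the compounds with values here, no measured step touches that part of the shared core, so nothing here points to a step beyond the scatter. Compound 4 is therefore expected to give about 10%, between 0% and 30%, a step of a number 1 percentage points higher from compound 1 to compound 4 (within the scatter) from compound 1 that is estimated to stay within the scatter.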

Compound 4, a percentage reported as inhibition, at one concentration (the size of the read-out at that concentration, not a potency): 5%
Compound 4: the middle estimate sits 5 percentage points above what was measured; the measured number falls inside the stated range.
By their numbers in this assay, from the lowest: compounds 3, 2, 4 and 1 (each within the scatter of the next).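

In this assay the change to 2,5-dimethoxyphenyl on the aromatic carbon of the five-membered ring gives a number 4 percentage points lower from compound 1 to compound 4 (within the scatter) and is the first step shown at this end of the shared core. Even this larger group, which has 0 hydrogen-bond donors, leaves the number within the scatter, so this position, like the group on the oxygen next to the carbonyl, shows no clear effect here. Nothing available explains this result. As far as these compounds go, whether an amine or a carboxylic acid on that phenyl ring would give a step beyond the scatter remains open.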